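The source may report more compounds than this note shows. Statements on the series, on what has been measured and on what is new or still open speak of the compounds shown alone.

Measured so far in a functional assay on HeLa cells (Homo sapiens) for cytotoxicity, read by MTT assay, with a stated time of 48 h; a lower number here means a stronger inhibitor, a higher number a weaker inhibitor:
compound 1 `COc1ccc(N/C(CCNC2=CC(=O)c3ccccc3C2=O)=N\S(=O)(=O)c2ccc(C)cc2)cc1`: 7590 nM
compound 2 `Cc1ccc(S(=O)(=O)/N=C(/CCNC2=CC(=O)c3ccccc3C2=O)Nc2ccccc2I)cc1`: 19100 nM
compound 3 `COc1cc(N/C(CCNC2=CC(=O)c3ccccc3C2=O)=N\S(=O)(=O)c2ccc(C)cc2)cc(OC)c1OC`: 3390 nM

Compound 3 gives the lowest number of the three. Its step from compound 1 is a 2.2-fold lower number from compound 1 to compound 3 (0.35 log units; beyond the scatter), and from compound 2 it is a 5.6-fold lower number from compound 2 to compound 3 (0.75 log units; beyond the scatter); both steps lie beyond the scatter, so compound 3 is the strongest inhibitor of this set in this assay. The step of a 2.5-fold higher number from compound 1 to compound 2 (0.40 log units; beyond the scatter) shows the two remaining aryl variants also separated beyond the scatter.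

Compound 4 `Cc1ccc(S(=O)(=O)/N=C(/CCNC2=CC(=O)c3ccccc3C2=O)NC(C)C)cc1` differs from compound 3 by isopropyl in place of 3,4,5-trimethoxyphenyl on an amine nitrogen, at an amine nitrogen whose other neighbour is a carbon with a double bond to nitrogen. All three measured steps exchange one aryl group for another on that same nitrogen; none removes the aromatic ring altogether, so they bear on this step only loosely. They do show that this position shifts the number by modest steps in either direction, and that the pattern giving the lowest number is the one that leaves here. A higher number than for compound 3 is therefore expected, of modest size and with a wide range, as a step of a 2.9-fold higher number from compound 3 to compound 4 (0.47 log units; beyond the scatter). For compound 4 the estimate in this assay is 10000 nM, within 3000 nM to 40000 nM.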

Compound 4, half-maximal inhibitory concentration: 30200 nM
For compound 4 the middle estimate is 3.0-fold (0.48 log units) below the measured one, and the stated range covers the measured number.
By their numbers in this assay, from the lowest: compound 3; then compound 1; then compounds 2 and 4 (each within the scatter of the next).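

In this assay, among the compounds shown here, isopropyl is the first group on this amine nitrogen that carries no aromatic ring, and the size of the step depends on which aryl group it replaces: an 8.9-fold higher number from compound 3 to compound 4 (0.95 log units; beyond the scatter), but a 4.0-fold higher number from compound 1 to compound 4 (0.60 log units; beyond the scatter) and a 1.6-fold higher number from compound 2 to compound 4 (0.20 log units; within the scatter). An aromatic ring at this position is therefore not enough on its own to give a low number, since the 2-iodophenyl group of compound 2 retains a ring and still stands within the scatter of the isopropyl group of compound 4. Within these four compounds, the lower numbers belong to the two methoxy-bearing aryl groups, with compound 3 lowest and compound 1 next, and compound 2 is the exception to any simple division between aryl and alkyl groups.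

No accompanying measurement bears on why these numbers differ. On these data alone, it remains open how a cyclohexyl ring, a benzyl group or a longer chain such as n-butyl on this nitrogen would compare, and whether any of them would reach the number of compound 3 without a methoxy-bearing aromatic ring.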